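A few compounds are considered here, and "the series" means these few. Any claim that something is new, unique, unknown or untested is made for them only; others in the source may bear on it.

In a functional assay on A549 cells (Homo sapiens) for inhibition, read by CCK-8 assay, with a stated time of 72 h, tested at 8 uM (on this read-out higher numbers stand for more inhibition of growth at the one concentration tested and lower numbers for less inhibition of growth), compound 2 (`CCc1ccc(SCc2ccc(/C=C/C(=O)Nc3ccccc3N)cc2)cc1`) gives 68.6%. For the measured compounds named here, this is the middle of the three numbers so far: compound 1 (`Nc1ccccc1NC(=O)/C=C/c1ccc(CSc2cccc(F)c2)cc1`) gives 56.6%, and compound 3 (`Nc1ccccc1NC(=O)c1ccc(CSc2nccc(C(F)(F)F)n2)cc1`) gives 95.1%. Both gaps to compound 2 lie beyond the usual scatter.

The next compound to be tested is compound 4 (`Nc1ccccc1NC(=O)/C=C/c1ccc(CSCCc2ccccc2)cc1`), which differs from compound 2 in one group: phenethyl in place of 4-ethylphenyl on a sulfur. The two compounds have the same atoms, joined differently, so the change reads (4-ethylphenyl)sulfanyl to phenethylsulfanyl.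

Going by the values given here, only one measured step bears on this change. It is a number 12 percentage points higher from compound 1 to compound 2 (beyond the scatter), a modest step beyond the scatter, with 4-ethylphenyl in place of 3-fluorophenyl on a sulfur. Among the compounds with values here, that step shows that a swap on this sulfur can move the number, but no measured compound carries phenethyl, so the direction of the new step remains uncertain. The size of a number 12 percentage points higher from compound 1 to compound 2 (beyond the scatter) therefore sets the expected scale, and a slight fall is the cautious guess. The expected change is a number 6.6 percentage points lower from compound 2 to compound 4 (within the scatter), an estimated step that need not exceed the scatter. For compound 4 the estimated value is 62%, with an expected range of 44% to 80%.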

Compound 4, percent growth inhibition at one concentration: 50.3%
Estimate against measurement, compound 4: 11.7 percentage points above; measured number inside the range.
By their numbers in this assay, from the lowest: compounds 4 and 1 (each within the scatter of the next); then compound 2; then compound 3.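

In this assay, phenethyl in place of 4-ethylphenyl gives a number 18.3 percentage points lower from compound 2 to compound 4 (beyond the scatter), so the group on this sulfur matters even when the two groups have the same atoms and differ only in how those atoms are joined. Set against 3-fluorophenyl, phenethyl gives a number 6.3 percentage points lower from compound 1 to compound 4 (within the scatter), which means that these two groups cannot be told apart here, while 4-ethylphenyl lies beyond the scatter from both and gives the highest number of the three groups. Nothing available explains why the joining of the atoms changes the number in this way.

Going by these compounds, whether a longer chain such as phenylpropyl, or a plain phenyl group, on this sulfur would give a number nearer that of compound 2 or that of compound 4 remains open. On these data alone, each number also comes from a single concentration, so the way these compounds compare at other concentrations is unknown.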